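The source may hold more compounds than are shown below. What is called first, only, known or untested is meant among the compounds shown, and "the series" means these compounds.

In a functional assay on Jurkat cells (Homo sapiens) for antiproliferative activity, read by MTT assay, with a stated time of 72 h (on this read-out higher numbers stand for weaker inhibition and lower numbers for stronger inhibition), compound 1 (`COc1cc(-c2ncnn2-c2cccc(F)c2)cc(OC)c1OC`) gives > 10000 nM as its reading, which is a limit of the assay and not a number. Among the compounds with values here, this places compound 1 at the limit of > 10000 nM in this assay, at which 1 of the 2 values shown sits, so far. Compound 2 (`CCOc1ccc(-c2ncnn2-c2cc(OC)c(OC)c(OC)c2)cc1Cl`) gives 3 nM in this assay as a true number. It differs from compound 1 in more than one place, so no single structural change can be read from these two results.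

Compound 3 (`COc1cc(-c2ncnn2-c2ccc(N)cc2)cc(OC)c1OC`) keeps the core of compound 1 and carries 4-aminophenyl in place of 3-fluorophenyl on an aromatic nitrogen. The counted difference is 4-aminophenyl in place of 3-fluorophenyl on an aromatic nitrogen for this swap. Within the data shown here, no measured step covers the change, so any forecast is loose. A move towards stronger inhibition is expected in this assay and would appear as a lower number, though its size is very uncertain. Compound 2 at 3 nM shows only that low values occur among these compounds. The expected change is an at least 12-fold lower number from compound 1 to compound 3 (1.09 log units; beyond the scatter) on this estimate, and a reading that again stops at the limit remains possible. For compound 3 the estimated value is 800 nM with an expected range from 30 nM to 10000 nM in this assay.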

Compound 3, half-maximal inhibitory concentration: > 10000 nM
Compound 3: no number, only a limit; the forecaster's own chance of this, stated with the estimate: 35%; at least 12-fold (1.09 log units) between middle value and limit.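

Compound 1 and compound 3 both stop at a limit of the assay and give no number, so no step can be read for 4-aminophenyl in place of 3-fluorophenyl: the limit of > 10000 nM in this assay, at which 2 of the 3 values shown sit.

The compounds shown leave open how far compound 1 and compound 3 lie beyond that limit, and whether this swap changes inhibition at all.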